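Trading 4-hydroxy-3-methoxyphenyl for 1H-indol-3-yl

A few compounds are considered here, and "the series" means these few. Any claim that something is new, unique, unknown or untested is made for them only; others in the source may bear on it.

In a functional assay on DU-145 cells (Homo sapiens) for inhibition, read by trypan blue exclusion, with a stated time of 96 h (a higher number here means a weaker inhibitor of growth, a lower number a stronger inhibitor of growth), compound 1 (`COc1cc(/C=C(/Sc2ccc(Br)cc2)C(=O)c2ccc(Br)cc2)ccc1O`) gives 1000 nM and stands level, within the scatter, with compound 2 (`O=C(/C(=C\c1ccc(Br)cc1)Sc1ccccc1Br)c1ccc(Br)cc1`), which reads 1000 nM as well. Compound 3 (`O=C(/C(=C\c1c[nH]c2ccccc12)Sc1ccc(Br)cc1)c1ccc(Br)cc1`) carries 1H-indol-3-yl in place of 4-hydroxy-3-methoxyphenyl on a double-bonded chain carbon bound to a double-bonded chain carbon. Within the data shown here, no measured step bears on this change, so no direction can be argued and no shift beyond the scatter is expected in this assay here. The estimated no change at the digits printed from compound 1 to compound 3 (within the scatter) therefore stays modest. For compound 3 the estimate is 1000 nM with an expected range from 300 nM to 3000 nM in this test.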

Compound 3, concentration for 50% growth inhibition: 1000 nM
Estimate against measurement, compound 3: no gap at the digits printed, and the stated range covers the measured number.
By their numbers in this assay, from the lowest: compounds 1, 2 and 3 (each within the scatter of the next).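

In this assay, 1H-indol-3-yl in place of 4-hydroxy-3-methoxyphenyl on a double-bonded chain carbon bound to a double-bonded chain carbon gives no change at the digits printed from compound 1 to compound 3 (within the scatter). This position therefore holds either a group with one six-membered aromatic ring and 2 hydrogen-bond acceptors or one with an additional five-membered aromatic ring and 0 acceptors, with no difference in growth inhibition beyond the scatter. Nothing measured here offers an explanation for this result. From the compounds shown here alone, whether an amine or a carboxylic acid at this position would shift growth inhibition remains open.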